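Compound 1 to compound 3: ethylcarbamoyl to carbamoyl

The compounds below may be only part of what the source reports. "The series", "measured", "known", "first", "only" and "open" are said of these compounds alone.

Working notes start from compound 1 `CCCCCOC(=O)N1CCN(C(=O)[C@H](CCC(=O)O)NC(=O)c2cc(N3CCC(C(=O)NCC)CC3)nc(-c3ccccc3)n2)CC1`, measured in an ADME assay on microsomes from liver (Rattus norvegicus) for metabolic stability; on this read-out higher numbers stand for a more stable compound and lower numbers for a less stable compound. Compound 1 gives > 80%, which is a limit and not a number. Compound 2 `CCCCCOC(=O)N1CCN(C(=O)[C@H](CCC(=O)O)NC(=O)c2cc(N3CCC(N4CCCC4)CC3)nc(-c3ccccc3)n2)CC1` gives > 80%, which is also a limit. The evidence so far is the limit of > 80% in this assay, at which 2 of the 2 values shown sit.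

Compound 3 `CCCCCOC(=O)N1CCN(C(=O)[C@H](CCC(=O)O)NC(=O)c2cc(N3CCC(C(N)=O)CC3)nc(-c3ccccc3)n2)CC1` differs from compound 1 as follows: hydrogen in place of ethyl on an amide-type nitrogen. In words, hydrogen stands in place of ethyl on an amide-type nitrogen, so ethylcarbamoyl becomes carbamoyl.

Among the compounds with values here, the only measured step is a step that the two limits leave unreadable from compound 1 to compound 2. It replaces the whole ethylcarbamoyl group with pyrrolidin-1-yl, and it offers no size to carry over. With both measured compounds at the limit, no step beyond the scatter is expected in this assay, in either direction. The expected step is a step that the limit leaves unreadable from compound 1 to compound 3. For compound 3 the estimated value is 86%, with an expected range from 70% to 98%.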

Compound 3, percent of the compound remaining: > 80%
Compound 3: no number, only a limit; the forecaster's own chance of this, stated with the estimate: 65%; the middle value is on the limit's open side.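

In this assay compound 3 gives > 80%, which is a limit and not a number. The steps to compound 3 from compound 1 and from compound 2 cannot be read. The compounds shown leave open whether compound 1, compound 2 and compound 3 differ at all in this assay: the limit of > 80% in this assay, at which 3 of the 3 values shown sit.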